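A few compounds are considered here, and "the series" means these few. Any claim that something is new, unique, unknown or untested is made for them only; others in the source may bear on it.

In an ADME assay on GM00637 cells (Homo sapiens) for cytotoxicity, read by MTT assay, with a stated time of 72 h (on this read-out higher numbers stand for weaker inhibition and lower numbers for stronger inhibition), compound 1 `O=c1ccc2nc(-c3ccccc3)nn(-c3ccccc3)c-2c1` gives 230 nM. Compound 2 `Nc1cc2nc(-c3ccccc3)nn(-c3ccccc3)c-2cc1=O` gives 2040 nM, with amino in place of hydrogen on an aromatic carbon, which is an 8.9-fold higher number from compound 1 to compound 2 (0.95 log units; beyond the scatter). Compound 3 `CCN(CC)c1cc2nc(-c3ccccc3)nn(-c3ccccc3)c-2cc1=O` gives 2730 nM, with diethylamino in place of hydrogen, which is a 12-fold higher number from compound 1 to compound 3 (1.07 log units; beyond the scatter). Compound 3 therefore stands level with compound 2, and both lie well above compound 1: the step between the two is a 1.3-fold higher number from compound 2 to compound 3 (0.13 log units; within the scatter).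

Compound 4 `O=c1cc2n(-c3ccccc3)nc(-c3ccccc3)nc-2cc1N1CCCCC1` has piperidin-1-yl in place of diethylamino on an aromatic carbon. Among the measured compounds shown here, no measured compound carries a ring at this place, so the closest guide is the exchange of one amino group for another, a 1.3-fold higher number from compound 2 to compound 3 (0.13 log units; within the scatter). The large steps from compound 1 replaced hydrogen, and this change does not. The expected result is no change beyond the scatter, an estimated 1.1-fold lower number from compound 3 to compound 4 (0.04 log units; within the scatter). In this assay, compound 4 is expected at 2500 nM, with an estimated range of 1200 nM to 5000 nM.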

Compound 4, half-maximal inhibitory concentration: 1190 nM
Estimate against measurement, compound 4: 2.1-fold (0.32 log units) above; measured number outside the range, below it.
By their numbers in this assay, from the lowest: compound 1; then compounds 4, 2 and 3 (each within the scatter of the next, the first and the last beyond it).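

In this assay, the kind of substituted amino group on this aromatic carbon matters: piperidin-1-yl in place of diethylamino gives a step beyond the scatter (a 2.3-fold lower number from compound 3 to compound 4 (0.36 log units; beyond the scatter)), whereas the exchange of amino for diethylamino had stayed within it. Against amino, the ring also stays within the scatter (a 1.7-fold lower number from compound 2 to compound 4 (0.23 log units; within the scatter)), so compound 4 cannot be ordered against compound 2. The ring does not restore the number of the compound with hydrogen at this place (a 5.2-fold higher number from compound 1 to compound 4 (0.71 log units; beyond the scatter)), and so all three groups at this position still stand beyond the scatter from hydrogen.

Nothing available explains why the ring and the open chain differ. As far as these compounds go, whether a smaller pyrrolidine ring, a morpholine ring or an acetamide at this place would follow piperidin-1-yl remains open.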